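Swapping the Ester Aryl Group: Chlorophenyl to Nitrophenyl

The source may hold more compounds than are shown below. What is called first, only, known or untested is meant among the compounds shown, and "the series" means these compounds.

Compound 1, `CC1=CCC2C(CC[C@@]2(C)O)C(C)(C)C1CC[C@@H]1[C@@]2(C)CCC(=O)C(C)(C)O[C@@H]2CC[C@]1(C)O`: > 50000 nM
Compound 2, `CC1=CC[C@H]2[C@H](CC[C@]2(C)O)C(C)(C)[C@@H]1CC[C@H]1[C@]2(C)CC[C@H](OC(=O)c3ccc(Cl)cc3)C(C)(C)O[C@H]2CC[C@@]1(C)O`: 10300 nM

In a functional assay on MDA-MB-231 cells (Homo sapiens) for antiproliferative activity, read by MTT assay, with a stated time of 72 h (on this read-out higher numbers stand for weaker inhibition and lower numbers for stronger inhibition), compound 1 gives only a limit, > 50000 nM, and no number. Within the data shown here, compound 2 gives 10300 nM in this assay, the only real number among the two values shown, while the limit of > 50000 nM in this assay, at which 1 of the 2 values shown sits, describes where the other value sits. Compound 3, `CC1=CC[C@H]2[C@H](CC[C@]2(C)O)C(C)(C)[C@@H]1CC[C@H]1[C@]2(C)CC[C@H](OC(=O)c3cccc([N+](=O)[O-])c3)C(C)(C)O[C@H]2CC[C@@]1(C)O`, has not been measured. It differs from compound 2 in a single place: 3-nitrophenyl in place of 4-chlorophenyl on a carbonyl carbon. Among the measured compounds shown here, no two measured compounds differ in only one place, so there is no measured step to compare this change against. For the measured compounds named here, with the single number for compound 2 as the only anchor, the step from compound 2 to compound 3 in this assay is expected to stay within the usual scatter, in no firm direction: a 1.0-fold lower number from compound 2 to compound 3 (0.01 log units; within the scatter). Compound 3 is therefore estimated at 10000 nM in this assay, with a range from 4000 nM to 30000 nM.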

Compound 3, half-maximal inhibitory concentration: 34700 nM
The estimate for compound 3 lay 3.5-fold (0.54 log units) below the measured number; measured number outside the range, above it.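

Among these compounds, this step is the first measured evidence that the aryl group of the ester matters. In this assay, 3-nitrophenyl in place of 4-chlorophenyl on a carbonyl carbon gives a 3.4-fold higher number from compound 2 to compound 3 (0.53 log units; beyond the scatter), so inhibition becomes weaker by a modest but real margin. Nothing measured here explains why the change weakens inhibition.

On these data alone, this single step swaps the substituent and its place on the ring together, so it remains open whether the nitro group itself or its place accounts for the shift, a question that 4-nitrophenyl and 3-chlorophenyl could help to separate. Also open, as far as these compounds go, is how the assay would read with an unsubstituted phenyl, an aminophenyl or a carboxylic acid on the same ring.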